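This account rests on a few compounds, and the source may have more. Where it says the series, first, only, none or still open, it means among the compounds named here.

Three measured compounds share a common acyl-semicarbazide framework built on a five-membered aromatic ring with one nitrogen and one sulfur, and were tested in a functional assay on HeLa cells (Homo sapiens) for inhibition, read by MTT assay, with a stated time of 72 h; a higher number here means a weaker inhibitor, a lower number a stronger inhibitor. Compound 1 `CN(C(=O)NC(=O)c1ccc(Cl)cc1Cl)c1nc(C(F)(F)F)c(C(=O)N/N=C/c2ccc(C(F)(F)F)cc2)s1` gives 7.99 ug/mL. Compound 2 `Cc1nc(N(C)C(=O)NC(=O)c2c(F)cccc2F)sc1C(=O)N/N=C/c1cc(C(F)(F)F)cc(C(F)(F)F)c1` gives 12.2 ug/mL. Compound 3 `Cc1nc(N(C)C(=O)NC(=O)c2ccc(Cl)cc2Cl)sc1C(=O)N/N=C/c1ccc(C(F)(F)F)cc1` gives 20.3 ug/mL.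

Compounds 3 and 1 differ in one place: trifluoromethyl in place of methyl on an aromatic carbon. That change produced a 2.5-fold lower number from compound 3 to compound 1 (0.40 log units; beyond the scatter), a modest step beyond the usual scatter. Compounds 2 and 3 differ in more than one place, and the difference between their two cores is not broken down here; their values sit within the scatter of each other.

Compound 4 `CN(C(=O)NC(=O)c1c(F)cccc1F)c1nc(C(F)(F)F)c(C(=O)N/N=C/c2cc(C(F)(F)F)cc(C(F)(F)F)c2)s1` has not yet been measured. It differs from compound 2 in exactly the same way: trifluoromethyl in place of methyl on an aromatic carbon. Among the compounds with values here, the place line matches word for word, so this is the same change as the one from compound 3 to compound 1.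

On the basis of that single earlier example, compound 4 is expected to move by a 2.2-fold lower number from compound 2 to compound 4 (0.35 log units; beyond the scatter) in this assay relative to compound 2, which gave 12.2 ug/mL. The estimate for compound 4 is 5.5 ug/mL, with a plausible range from 2.5 ug/mL to 12 ug/mL, resting only on one precedent.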

Compound 4, half-maximal inhibitory concentration: 5.62 ug/mL
Compound 4: the middle estimate sits 1.0-fold (0.01 log units) below what was measured; low and high end bracket the measured number.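

In this assay, putting trifluoromethyl in place of methyl on the ring carbon gave a 2.2-fold lower number from compound 2 to compound 4 (0.34 log units; beyond the scatter), and this step closely matches the earlier one made on a different core: the same change on two cores in this assay, a 2.5-fold lower number (0.40 log units; beyond the scatter) from compound 3 to compound 1 and a 2.2-fold lower number (0.34 log units; beyond the scatter) from compound 2 to compound 4, 1.2-fold (0.07 log units) apart, within the scatter of two such steps

So on these two pairs, the change carried over from one core to the other with much the same size and in the same direction, even though the groups elsewhere in the molecules differ. Two pairs in a single cell assay do not make a general rule, however, and they neither explain why the number falls nor show that the step would hold on other cores in the series.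

From the compounds shown here alone, only methyl and trifluoromethyl stand on this ring carbon here, so it remains open how an ethyl group, an amine or a carboxylic acid in the same place would read. Whether the step would keep its size in a different kind of assay is also left open.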